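The source may report more compounds than this note shows. Statements on the series, on what has been measured and on what is new or still open speak of the compounds shown alone.

Working notes on the series. In an assay on CHO cells for displacement of a labelled ligand from adenosine receptor A3 (Homo sapiens) (a lower number here means a stronger inhibitor, a higher number a weaker inhibitor), compound 1 `O=C(NCC1CC1)[C@H]1O[C@@H](n2cnc3c(NCc4cccc(I)c4)nc(Cl)nc32)[C@H](O)[C@@H]1O` gives 3.63 nM and compound 2 `CNC(=O)[C@H]1O[C@@H](n2cnc3c(NCc4ccccc4C)nc(Cl)nc32)[C@H](O)[C@@H]1O` gives 2.19 nM. Going by the values given here, compound 3 `Cc1ccccc1CNc1nc(Cl)nc2c1ncn2[C@@H]1O[C@H](C(=O)NC2CC2)[C@@H](O)[C@H]1O` gives 27.5 nM in this assay, the highest of the three numbers so far. Among the compounds with values here, the one step measured on the amide-type nitrogen, a 13-fold higher number from compound 2 to compound 3 (1.10 log units; beyond the scatter), shows that enlarging the amide substituent from methyl to cyclopropyl costs potency. Compound 4 `Cc1ccccc1CNc1nc(Cl)nc2c1ncn2[C@@H]1O[C@H](C(=O)NCC2CC2)[C@@H](O)[C@H]1O` carries the change (cyclopropylmethyl in place of cyclopropyl on an amide-type nitrogen). Within the data shown here, no measured step covers exactly this change, but compound 1 carries the same cyclopropylmethyl amide on a differently substituted benzyl group and shows a low number, 3.63 nM, in this assay. On that basis the expected step is a 5.5-fold lower number from compound 3 to compound 4 (0.74 log units; beyond the scatter), toward a lower number. Compound 4 is expected to give about 5 nM, estimated between 2 nM and 15 nM.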

Compound 4, inhibition constant: 29.5 nM
Compound 4: the middle estimate sits 5.9-fold (0.77 log units) below what was measured; measured number above the stated range.
By their numbers in this assay, from the lowest: compounds 2 and 1 (each within the scatter of the next); then compounds 3 and 4 (each within the scatter of the next).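

In this assay, cyclopropylmethyl and cyclopropyl on the amide-type nitrogen cannot be told apart with the 2-methylphenyl group (a 1.1-fold higher number from compound 3 to compound 4 (0.03 log units; within the scatter)), and the larger amide does not recover what is lost relative to methyl (a 13-fold higher number from compound 2 to compound 4 (1.13 log units; beyond the scatter)). The low number of compound 1 therefore does not carry over with its amide alone: with the cyclopropylmethyl amide held constant, the benzyl change matters (an 8.1-fold higher number from compound 1 to compound 4 (0.91 log units; beyond the scatter)). No evidence is available on the reason for this. Open, as far as these compounds go, is how the methyl amide behaves with the 3-iodophenyl group, and whether a longer chain or an amine on the amide-type nitrogen would behave like cyclopropyl.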